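This account rests on a few compounds, and the source may have more. Where it says the series, first, only, none or still open, it means among the compounds named here.

Going by the values given here, in an in vitro assay on cells for inhibition of Amine oxidase [flavin-containing] B (Homo sapiens), read by fluorescence and Amplex Red, with stated times of 30 min and 45 min (on this read-out higher numbers stand for weaker inhibition and lower numbers for stronger inhibition), compound 3 `O=C(CCCc1ccccc1)Nc1nc2ccccc2c(=O)s1` gives 34.9 nM, the lowest of the three numbers measured so far. Compound 2 `O=C(CCCc1ccccc1)Nc1nc2cc(Cl)ccc2c(=O)s1` gives 76.4 nM, and compound 1 `COc1cccc(CCCC(=O)Nc2nc3ccccc3c(=O)s2)c1` gives 389 nM. Both measured steps toward compound 3 involve a change on an aromatic carbon: a 2.2-fold lower number from compound 2 to compound 3 (0.34 log units; beyond the scatter) and an 11-fold lower number from compound 1 to compound 3 (1.05 log units; beyond the scatter). Compound 4 `O=C(CCc1ccccc1)Nc1nc2ccccc2c(=O)s1` differs from compound 3 in a different way: phenyl in place of benzyl on a saturated chain carbon, two bonds along the chain from a carbonyl carbon. Among the compounds with values here, neither measured step touches the saturated chain, so no measured step bears directly on this change, and its size and direction cannot be read from the data. The expected step is therefore a 1.7-fold higher number from compound 3 to compound 4 (0.24 log units; within the scatter), with wide bounds. Compound 4 is estimated at 60 nM, with a range from 15 nM to 250 nM.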

Compound 4, half-maximal inhibitory concentration: 17.6 nM
The estimate for compound 4 lay 3.4-fold (0.53 log units) above the measured number, within the range that was stated.
By their numbers in this assay, from the lowest: compounds 4 and 3 (each within the scatter of the next); then compound 2; then compound 1.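

In this assay, phenyl in place of benzyl on a saturated chain carbon, two bonds along the chain from a carbonyl carbon, gives a 2.0-fold lower number from compound 3 to compound 4 (0.30 log units; within the scatter), so the two compounds cannot be told apart. Going by these compounds alone, this is the first measured step on the saturated chain, and it shows that this change leaves the number within the scatter, whereas the earlier steps all lay on aromatic carbons. No measurement shown accounts for this result.
As far as these compounds go, what a longer chain would do stays open, and so does the effect of an amine or a carboxylic acid on the saturated chain.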